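The compounds below may be only part of what the source reports. "The series", "measured", "known", "first", "only" and "open" are said of these compounds alone.

Going by the values given here, compound 2 `O=C(CSc1nnnn1-c1cccc2ccccc12)N/N=C/c1ccccc1Cl` is the one compound of this set that gives a plain number in an ADME assay on MT4 cells (Homo sapiens) for cytotoxicity, read by MTT assay; on this read-out higher numbers stand for lower toxicity in this test and lower numbers for higher toxicity in this test: compound 2 gives 69700 nM. Compound 1 `O=C(CSc1nnnn1-c1cccc2ccccc12)N/N=C/c1ccc(Cl)cc1` reaches only a limit in this assay, since compound 1 gives > 295000 nM, which is the limit of > 295000 nM in this assay, at which 1 of the 2 values shown sits. Compound 3 `O=C(CSc1nnnn1-c1cccc2ccccc12)N/N=C/c1ccc(F)cc1` differs from compound 2 by 4-fluorophenyl in place of 2-chlorophenyl on a carbon with a double bond to nitrogen. Among the compounds with values here, the one measured step that bears on this change ran in the opposite sense, an at least 4.2-fold lower number from compound 1 to compound 2 (0.62 log units; beyond the scatter), and it lay beyond the scatter. Because compound 3, like compound 1, carries a 4-halophenyl rather than a 2-chlorophenyl, a step back toward a higher number is expected, roughly as large as a 2.6-fold higher number from compound 2 to compound 3 (0.41 log units; beyond the scatter). The fluorine in place of chlorine leaves some uncertainty, and the read-out may again end at a limit. Compound 3 is therefore estimated at 180000 nM, with a range from 60000 nM to 350000 nM.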

Compound 3, half-maximal cytotoxic concentration: > 307000 nM
Compound 3: a limit, no number; the forecaster's own chance of this, stated with the estimate: 40%; at least 1.7-fold (0.23 log units) between middle value and limit.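

In this assay, 4-fluorophenyl in place of 2-chlorophenyl on a carbon with a double bond to nitrogen gives an at least 4.4-fold higher number from compound 2 to compound 3 (0.64 log units; beyond the scatter). Compound 3 ends at a limit and not at a number: the limit of > 307000 nM in this assay, at which 1 of the 3 values shown sits. Among the three compounds, the 4-chlorophenyl of compound 1 and the 4-fluorophenyl of compound 3 both end at limits, while only the 2-chlorophenyl of compound 2 gives a number, so the step seen earlier is no longer tied to a single 4-substituted group.

Going by these compounds, the step from chloro to fluoro cannot be read, as compound 1 and compound 3 are both limits, and how far either compound lies past its limit stays open. Also open, on these data alone, is whether 2-fluorophenyl at this place would read like 2-chlorophenyl, and how a phenyl carrying an amine or a carboxylic acid would read.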